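The compounds below may be only part of what the source reports. "The series", "measured", "known", "first", "only" and "open" are said of these compounds alone.

Two compounds of a shared core, `COc1ccc2cc(C(C)c3nnc4n3N=C(c3ccc(OC(F)(F)F)cc3)CS4)ccc2c1` for compound 1 and `COc1ccc2cc(C(C)c3n[nH]c(=S)n3N)ccc2c1` for compound 2, have been measured in a functional assay on MCF7 cells (Homo sapiens) for inhibition, read by sulforhodamine B assay, with a stated time of 72 h; on this read-out lower numbers stand for stronger inhibition and higher numbers for weaker inhibition. Compound 1 stands as the lower of the two numbers: in this assay compound 1 gives 8800 nM, and the closest number is that of compound 2, which in this assay gives 22300 nM, a gap that lies beyond the usual scatter. Among the compounds with values here, no pair of measured compounds differs in only one place, so no single structural step can be read from the numbers so far.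

Compound 3, `COc1ccc2cc(C(C)c3nnc4n3N=C(c3ccc(Cl)cc3)CS4)ccc2c1`, has not yet been measured. It differs from compound 1 in one place: chloro in place of trifluoromethoxy on an aromatic carbon. Nothing in the two measured compounds tells how such an exchange on this aryl group shifts the read-out, so the step from compound 1 to compound 3 is expected to be modest, most likely within the scatter, with a slight lean toward a higher number, which is written as a 1.1-fold higher number from compound 1 to compound 3 (0.06 log units; within the scatter). Compound 3 is therefore estimated at 10000 nM, with a range from 4000 nM to 25000 nM.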

Compound 3, half-maximal inhibitory concentration: 10100 nM
Compound 3: middle estimate off by 1.0-fold (0.00 log units), on the low side; measured number inside the range.
By their numbers in this assay, from the lowest: compounds 1 and 3 (each within the scatter of the next); then compound 2.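

In this assay, within the data shown here, replacing 4-(trifluoromethoxy)phenyl with 4-chlorophenyl gives a 1.1-fold higher number from compound 1 to compound 3 (0.06 log units; within the scatter), the only single-place step that can be read in this set. On this aromatic carbon, para to a large group, a trifluoromethoxy group of 5 heavy atoms with 1 hydrogen-bond acceptor and a chloro group of 1 heavy atom with no hydrogen-bond acceptor are therefore not told apart by this read-out, so the exchange of these two groups leaves the number where the scatter cannot separate it. Nothing measured alongside these compounds bears on why this exchange gives such a step.

The compounds shown leave open how an amine, a carboxylic acid, a methoxy group or a bare hydrogen on this same aromatic carbon would read, and so whether any group at this position moves the number beyond the scatter. They also leave open what a change elsewhere on the shared core, such as at its methoxy group, would do, since both single-place partners here differ only on the aryl group.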